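Furan in Place of Thiophene on the Cyclopropane Carbon

The compounds below may be only part of what the source reports. "The series", "measured", "known", "first", "only" and "open" are said of these compounds alone.

Two measured compounds share one core and differ only in the aromatic ring attached to a saturated ring carbon. Compound 1 `CC[C@H](C)[C@H](N)CN(C(=O)[C@@H]1C[C@H]1c1ccc(F)c(F)c1)c1ccc(-c2ccccc2)cc1` carries a 3,4-difluorophenyl there, and in a functional assay for agonist activity at G protein-coupled receptor 88 (Homo sapiens), read by HTRF and cAMP accumulation (on this read-out lower numbers stand for an effect already at smaller amounts and higher numbers for an effect only at larger amounts of compound), compound 1 gives 720 nM. Compound 2 `CC[C@H](C)[C@H](N)CN(C(=O)[C@@H]1C[C@H]1c1ccsc1)c1ccc(-c2ccccc2)cc1` carries a thiophen-3-yl instead, and in this assay compound 2 gives 450 nM. The step of a 1.6-fold lower number from compound 1 to compound 2 (0.20 log units; within the scatter) is within the scatter, so compound 2 has the smaller of the two numbers without standing apart from compound 1. Compound 3 `CC[C@H](C)[C@H](N)CN(C(=O)[C@@H]1C[C@H]1c1ccoc1)c1ccc(-c2ccccc2)cc1` has not yet been measured; the change from compound 2 is furan-3-yl in place of thiophen-3-yl on a saturated ring carbon. Among the compounds with values here, only the step from compound 1 to compound 2 bears on this change, and it stayed within the scatter. For compound 3 the expected step is therefore a 1.3-fold higher number from compound 2 to compound 3 (0.12 log units; within the scatter), small and if anything toward a higher number. The estimate for compound 3 in this assay is 600 nM, with a range from 250 nM to 1500 nM.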

Compound 3, half-maximal effective concentration: 580 nM
Compound 3: middle estimate off by 1.0-fold (0.01 log units), on the high side; low and high end bracket the measured number.
By their numbers in this assay, from the lowest: compounds 2, 3 and 1 (each within the scatter of the next).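

In this assay, furan-3-yl in place of thiophen-3-yl gives a 1.3-fold higher number from compound 2 to compound 3 (0.11 log units; within the scatter) and furan-3-yl in place of 3,4-difluorophenyl gives a 1.2-fold lower number from compound 1 to compound 3 (0.09 log units; within the scatter) and so all three pairs of compounds now lie within the scatter of one another. The earlier pair alone could not show this: with a third ring on this saturated ring carbon, sulfur and oxygen as the hetero atom of a five-membered aromatic ring cannot be told apart here, and neither five-membered ring can be told apart from 3,4-difluorophenyl. Nothing measured beyond these numbers explains the similar readings.

From the compounds shown here alone, whether a group of another kind on this carbon, such as an amine, a carboxylic acid or a longer chain, would stand apart from these three remains open. So does whether the same swaps would read alike on a different core.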